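Bromo on the benzyl group of compound 2: expected inhibition

The source may hold more compounds than are shown below. What is called first, only, known or untested is meant among the compounds shown, and "the series" means these compounds.

Two measured compounds open the series. Compound 1 `C#CCOc1ccc(/C=C/C(=O)c2ccc(Br)cc2)cc1` is tested in a functional assay on HepG2 cells (Homo sapiens) for inhibition, read by MTT assay, with a stated time of 48 h, tested at 10 uM (on this read-out lower numbers stand for less inhibition of growth and higher numbers for more inhibition of growth at the one concentration tested), and gives 22%. Compound 2 `O=C(/C=C/c1ccc(OCc2cn(Cc3ccccc3)nn2)cc1)c1ccc(Br)cc1` carries a longer ether arm ending in a benzyl group in place of the short alkyne ether; in this assay compound 2 gives 22%. Compound 2 thus stands level with compound 1 at the digits shown, the gap between the two lying within the scatter, so neither can be called more or less active than the other.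

Compound 3 `O=C(/C=C/c1ccc(OCc2cn(Cc3cccc(Br)c3)nn2)cc1)c1ccc(Br)cc1` is not yet measured. It differs from compound 2 by bromo in place of hydrogen on an aromatic carbon; the benzyl becomes 3-bromobenzyl. Among the compounds with values here, no measured pair in the set isolates such a change, so the numbers point to no direction. Both measured compounds sit at the same modest level of growth inhibition, and the bromine enters on the benzyl group far from the shared core; no step beyond the scatter is expected from compound 2 to compound 3. The expected step is a number 2 percentage points higher from compound 2 to compound 3 (within the scatter). Compound 3 is accordingly estimated at 24% in this assay, with a range from 10% to 40%.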

Compound 3, percent growth inhibition at one concentration: 25%
For compound 3 the middle estimate is 1 percentage points below the measured one; measured number inside the range.
By their numbers in this assay, from the lowest: compounds 1, 2 and 3 (each within the scatter of the next).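

In this assay, bromo in place of hydrogen on an aromatic carbon of the benzyl group gives a number 3 percentage points higher from compound 2 to compound 3 (within the scatter). Within the data shown here, this is the first measured pair that isolates a single change, and it shows that 3-bromobenzyl can stand in place of benzyl, with the bromo meta to a large group, without a step beyond the scatter; one added heavy atom at this place does not separate compound 3 from compound 2. No measured information bears on this result, so the reading remains an observation without an explanation.

Still open, as far as these compounds go, is whether another group at this same place, such as an amine or a carboxylic acid, would give a step beyond the scatter, since a single bromo cannot show how broadly this place accepts change. Also open, from the compounds shown here alone, is whether the benzyl group contributes to the reading at all, which could be tested by a pair in which a longer alkyl chain stands in place of the benzyl group on the ether arm of compound 2.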